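Nitro to methoxy on the stereodefined lactone: expected cytotoxicity

The source may report more compounds than this note shows. Statements on the series, on what has been measured and on what is new or still open speak of the compounds shown alone.

Three compounds of this series carry a number in a functional assay on HL-60 cells (Homo sapiens) for cytotoxicity, read by MTT assay, with a stated time of 48 h; a lower number here means a stronger inhibitor, a higher number a weaker inhibitor. Among the measured compounds shown here, compound 1 `C=C1C(=O)OC(C)CC1c1ccc([N+](=O)[O-])cc1` gives 6120 nM and compound 2 `C=C1C(=O)OC(C)CC1c1ccc(Br)cc1` gives 4770 nM; the single one-place step, a 1.3-fold lower number from compound 1 to compound 2 (0.11 log units; within the scatter), is bromo in place of nitro on an aromatic carbon and stays within the scatter. Compound 3 `C=C1C(=O)O[C@H](C)[C@@H]1c1ccc([N+](=O)[O-])cc1` is the stereodefined analogue of compound 1. In this assay compound 3 gives 21700 nM, the highest of the three numbers, a gap beyond the scatter to compound 1 and a larger one to compound 2.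

The step under consideration is methoxy in place of nitro on an aromatic carbon, leading to compound 4 `C=C1C(=O)O[C@H](C)[C@@H]1c1ccc(OC)cc1`. For the measured compounds named here, no measured pair swaps nitro for methoxy, so only the bromo-for-nitro step bears on it indirectly, and that step was within the scatter. The stereodefined core of compound 3 is kept, so the reference point is its own value rather than that of compound 1 or compound 2.

On this basis no step beyond the scatter is expected from compound 3 to compound 4 in this assay, the estimated shift being a 1.1-fold lower number from compound 3 to compound 4 (0.04 log units; within the scatter). Compound 4 is therefore estimated at 20000 nM in this assay, with a range from 8000 nM to 50000 nM.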

Compound 4, half-maximal inhibitory concentration: 4820 nM
Beside the measured number, compound 4's estimate is 4.1-fold (0.62 log units) above it; measured number outside the range, below it.
By their numbers in this assay, from the lowest: compounds 2, 4 and 1 (each within the scatter of the next); then compound 3.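

Nitro is not interchangeable at this place on the aromatic ring: in this assay, methoxy in place of nitro on the core of compound 3 gives a 4.5-fold lower number from compound 3 to compound 4 (0.65 log units; beyond the scatter), a step beyond the scatter and the only such step at this position so far. The earlier step, a 1.3-fold lower number from compound 1 to compound 2 (0.11 log units; within the scatter), with bromo in place of nitro on the core of compound 1, stayed within the scatter, so replacing nitro does not move the number by the same amount in every case. Nothing available on the compounds accounts for this difference between the two steps.

The two steps differ in both the entering group and the core, so the compounds shown leave open whether the larger shift belongs to methoxy itself or to the core of compound 3. Bromo on the core of compound 3 and methoxy on the core of compound 1 would separate these two readings, while an amine or a carboxylic acid at the same place would show how far the response in this assay extends beyond the groups seen here.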